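The source may hold more compounds than are shown below. What is called first, only, known or untested is meant among the compounds shown, and "the series" means these compounds.

Within the data shown here, in a functional assay on SW480 cells (Homo sapiens) for antiproliferative activity, read by MTT assay, with a stated time of 48 h (a lower number here means a stronger inhibitor, a higher number a weaker inhibitor), compound 2 (`CC(C)=CCC[C@]1(C)/C=C/[C@@H](OC(=O)C=C(C)C)[C@](C)(O)/C=C/C(=O)/C(C(=O)N(C(C)C)C(C)C)=C\C1`) gives 16000 nM, the higher of the two numbers so far, and compound 1 (`CC(C)=CCC[C@]1(C)/C=C/[C@@H](OC(=O)C=C(C)C)[C@](C)(O)/C=C/C(=O)/C(C[Si](C)(C)C(C)(C)C)=C\C1`) gives 3350 nM. Compound 3 (`CC(C)=CCC[C@]1(C)/C=C/[C@@H](OC(=O)C=C(C)C)[C@](C)(O)/C=C/C(=O)/C(C(=O)N2CCCC2)=C\C1`) keeps the shared core and differs at one place: pyrrolidin-1-yl in place of diisopropylamino on a carbonyl carbon. In words, pyrrolidin-1-yl stands in place of diisopropylamino on a carbonyl carbon. Among the measured compounds shown here, the only measured step, a 4.8-fold higher number from compound 1 to compound 2 (0.68 log units; beyond the scatter), exchanges a whole group on a double-bonded ring carbon. For the measured compounds named here, no measured step changes the amino part alone, so this step bears on the present change only loosely, and a large move is not expected. The expected step is a 1.6-fold lower number from compound 2 to compound 3 (0.20 log units; within the scatter), small, towards a lower number and probably not beyond the scatter. For compound 3 the estimated value is 10000 nM, with an expected range of 3500 nM to 30000 nM.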

Compound 3, half-maximal inhibitory concentration: 15100 nM
Compound 3: middle estimate off by 1.5-fold (0.18 log units), on the low side; low and high end bracket the measured number.
By their numbers in this assay, from the lowest: compound 1; then compounds 3 and 2 (each within the scatter of the next).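

In this assay, among these compounds, the first change confined to the amino part of the amide, pyrrolidin-1-yl in place of diisopropylamino on a carbonyl carbon, gives a 1.1-fold lower number from compound 2 to compound 3 (0.03 log units; within the scatter) and so does not separate the two amides. The ring-closed amide also stands apart from the non-amide group of compound 1, with a 4.5-fold higher number from compound 1 to compound 3 (0.65 log units; beyond the scatter) in this assay, so the open-chain and ring amides both differ from that group in the same direction. No measurement of any property accompanies these numbers, so the result comes with no explanation.

Open, as far as these compounds go, is whether any amine on this carbonyl carbon, such as morpholin-4-yl or piperidin-1-yl, would separate from these two amides. Also open, from the compounds shown here alone, is how a carboxylic acid or a methyl ester at this place would compare with them.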